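Swapping the Pyrazole for a Pyridine at the Amide Tail

The source may hold more compounds than are shown below. What is called first, only, known or untested is meant among the compounds shown, and "the series" means these compounds.

Measured compounds in a functional assay on MV4-11 cells (Homo sapiens) for antiproliferative activity, with a stated time of 6 days, tested at 6.25 uM; on this read-out lower numbers stand for a weaker effect and higher numbers for a stronger effect at the one concentration tested:
compound 1 `CNC(=O)N1CCCc2ccc(NC(=O)c3cccc(-c4cnn(C)c4)c3)cc21` gives 93.5%
compound 2 `CNC(=O)N1CCCc2ccc(NC(=O)c3ccc(-c4cnn(C)c4)cc3)cc21` gives 94.4%
compound 3 `CNC(=O)N1CCCc2ccc(NC(=O)c3cccc(-c4cnn(S(C)(=O)=O)c4)c3)cc21` gives 18%

Compound 2 stands highest of the three numbers, but its nearest neighbour, compound 1, sits within the usual scatter of it, so the two cannot be told apart; compound 3 lies far beneath both.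

Compound 4 `CNC(=O)N1CCCc2ccc(NC(=O)c3ccc(-c4cccnc4)cc3)cc21` has not yet been measured. It differs from compound 2 in one place: pyridin-3-yl in place of 1-methyl-1H-pyrazol-4-yl on an aromatic carbon.

Among the compounds with values here, only one measured step is available, a number 75.5 percentage points lower from compound 1 to compound 3 (beyond the scatter), and it concerns a different change, the group on the aromatic nitrogen rather than the ring itself. It therefore does not speak directly to the pyridine-for-pyrazole exchange. The values of compound 1 and compound 2 show that the attachment point of the 1-methyl-1H-pyrazol-4-yl on the benzene ring leaves the read-out unchanged within scatter, which hints that this part of the molecule tolerates some variation.

Within the data shown here, with no directly bearing step, compound 4 is expected to stay near compound 2, with a modest downward step at most, a number 14.4 percentage points lower from compound 2 to compound 4 (beyond the scatter). The estimate for compound 4 in this assay is 80%, expected to fall between 40% and 98%.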

Compound 4, a percentage reported as inhibition, at one concentration (the size of the read-out at that concentration, not a potency): 92.1%
Beside the measured number, compound 4's estimate is 12.1 percentage points below it, within the range that was stated.
By their numbers in this assay, from the lowest: compound 3; then compounds 4, 1 and 2 (each within the scatter of the next).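

In this assay exchanging the 1-methyl-1H-pyrazol-4-yl for pyridin-3-yl gives a number 2.3 percentage points lower from compound 2 to compound 4 (within the scatter) so compound 2 and compound 4 cannot be told apart. The earlier compounds shown here varied only where the pyrazole was attached and what was carried on its nitrogen, whereas this pair changes the ring itself, on an aromatic carbon para to a large group. A five-membered aromatic ring with 2 hetero atoms and a six-membered aromatic ring with 1 hetero atom are therefore interchangeable at this place on this read-out, though no measurement here accounts for that.

The read-out reports the size of the effect at one concentration, so it leaves open whether compound 2 and compound 4 would differ in potency across a range of concentrations. Also open, going by these compounds, is how far this tolerance extends at the same aromatic carbon, for example to a morpholine, a carboxylic acid or a simple amine in place of the aromatic ring.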